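Replacing methyl on the sulfonyl sulfur of compound 3

The source may report more compounds than this note shows. Statements on the series, on what has been measured and on what is new or still open speak of the compounds shown alone.

In an ADME assay on MDCK cells (Canis lupus familiaris) for cytotoxicity, with a stated time of 48 h (a higher number here means that more compound is tolerated, a lower number that less compound is tolerated), compound 1 `C=C(C(=O)OC)[C@@H]1CC[C@H](C)[C@H]2C(=C(C)C(=O)[C@H]2NC(C)=O)C1` gives 753 uM and compound 2 `C=C(C(=O)OC)[C@@H]1CC[C@H](C)[C@H]2C(=C(C)C(=O)[C@H]2NC(=O)C(C)CCl)C1` gives 735 uM. Compound 3 `C=C(C(=O)OC)[C@@H]1CC[C@H](C)[C@H]2C(=C(C)C(=O)[C@H]2NS(C)(=O)=O)C1` gives 226 uM, the lowest number of the three. Compound 4 `C=C(C(=O)OC)[C@@H]1CC[C@H](C)[C@H]2C(=C(C)C(=O)[C@H]2NS(=O)(=O)c2ccc(F)cc2)C1` keeps the sulfonyl group but carries 4-fluorophenyl in place of methyl on a sulfonyl sulfur.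

Within the data shown here, no measured step changes this group directly, so the evidence is indirect. Introducing methylsulfonyl gave a 3.3-fold lower number from compound 1 to compound 3 (0.52 log units; beyond the scatter), and the second comparison gave a 3.3-fold lower number from compound 2 to compound 3 (0.51 log units; beyond the scatter). Both are modest steps. A larger group on a carbonyl carbon gave a 1.0-fold lower number from compound 1 to compound 2 (0.01 log units; within the scatter), so that enlargement left the number within the scatter. Among the measured compounds shown here, none of the measured compounds carries an aromatic ring, which leaves the direction uncertain, and only a modest further fall is anticipated. The expected size is a 1.9-fold lower number from compound 3 to compound 4 (0.27 log units; within the scatter). For compound 4 the estimated value is 120 uM, with an expected range from 40 uM to 300 uM.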

Compound 4, half-maximal toxic concentration: 25.1 uM
Compound 4: the middle estimate sits 4.8-fold (0.68 log units) above what was measured; the measured number lies below the stated range.
By their numbers in this assay, from the lowest: compound 4; then compound 3; then compounds 2 and 1 (each within the scatter of the next).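

In this assay, among these compounds, 4-fluorophenyl in place of methyl on a sulfonyl sulfur gives a 9.0-fold lower number from compound 3 to compound 4 (0.95 log units; beyond the scatter) and this is a larger step than any seen among the earlier compounds, so the group on this sulfur can move the number further than the exchange of acetyl for methylsulfonyl did. Against the two amides the distance becomes large, with a 30-fold lower number from compound 1 to compound 4 (1.48 log units; beyond the scatter) against the acetyl amide and a 29-fold lower number from compound 2 to compound 4 (1.47 log units; beyond the scatter) against the chlorine-bearing amide, which places compound 4, the only one of the four with an aromatic ring, lowest of the set. No measurement at hand gives a reason for this fall.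

The compounds shown leave open whether the fall follows the aromatic ring itself or its fluorine. Plain phenyl on the sulfonyl sulfur, or an ethyl or longer chain there, would help to separate these readings.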